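The source may hold more compounds than are shown below. What is called first, only, known or untested is meant among the compounds shown, and "the series" means these compounds.

In an ADME assay on a cell-free system (plasma, Mus musculus) for protein binding, compound 1 `CNc1nccc(N2CC[C@H](NC(=O)Nc3cccc(C#N)c3)C2)n1` gives 91.5%, and compound 2 `CNc1nccc(N2CC[C@H](NC(=O)Nc3ccc(CN4CCC4)c(C(F)(F)F)c3)C2)n1` gives 85.6%. These two values lie within the usual scatter of each other, so the measurements do not separate compound 2 from compound 1. Compound 3 `CNc1nccc(N2CC[C@H](NC(=O)Nc3ccc(CN4CCN(C)CC4)c(C(F)(F)F)c3)C2)n1` differs from compound 2 in one group: 4-methylpiperazin-1-yl in place of azetidin-1-yl on a saturated chain carbon bound to an aromatic carbon. Within the data shown here, no measured pair shows what such a swap does, so no shift beyond the scatter is expected in this assay. The expected change is a 1.1-fold higher unbound fraction from compound 2 to compound 3 (0.05 log units; within the scatter). For compound 3 the estimated value is 84%, with an expected range from 68% to 93%.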

Compound 3, plasma protein binding: 85.8%
Estimate against measurement, compound 3: 1.1-fold (0.05 log units) (unbound fraction) above; low and high end bracket the measured number.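

The saturated chain carbon bound to an aromatic carbon now has its first measured swap: in this assay, 4-methylpiperazin-1-yl in place of azetidin-1-yl gives a 1.0-fold lower unbound fraction from compound 2 to compound 3 (0.01 log units; within the scatter). For this one pair, a six-membered ring with 2 hetero atoms and a four-membered ring with 1 hetero atom cannot be told apart by this read-out. Nothing available explains this outcome. From the compounds shown here alone, whether an open-chain dimethylamino group or a carboxylic acid at this place would also stay within the scatter remains open.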